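Piperidin-1-yl for dimethylamino: from compound 2 to compound 4

The source may report more compounds than this note shows. Statements on the series, on what has been measured and on what is new or still open speak of the compounds shown alone.

In an ADME assay on L6 cells (Rattus norvegicus) for cytotoxicity, read by resazurin assay, with a stated time of 72 h (a higher number here means a weaker inhibitor, a lower number a stronger inhibitor), compound 2 (`CN1CCN(CCC(=O)N2CCC3(N(C)C)CC(c4ccccc4)C2C(c2ccccc2)C3)CC1`) gives 128000 nM among three measured numbers. Compound 3 (`CN1CCN(CC(=O)N2CCC3(N(C)C)CC(c4ccccc4)C2C(c2ccccc2)C3)CC1`) gives 195000 nM and sits within the scatter of compound 2. Compound 1 (`CN1CCN(CC(=O)OC2CC3(N(C)C)CC(c4ccccc4)C2C(c2ccccc2)C3)CC1`) gives 39900 nM as a lower number than compound 2, and that gap lies beyond the scatter.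

Compound 4 (`CN1CCN(CCC(=O)N2CCC3(N4CCCCC4)CC(c4ccccc4)C2C(c2ccccc2)C3)CC1`) carries one change from compound 2: piperidin-1-yl in place of dimethylamino on a saturated ring carbon with piperidin-1-yl in place of dimethylamino on a saturated ring carbon of the shared core. Among the measured compounds shown here, only one measured step compares compounds differing in one place, and it concerns another part of the structure: a 1.5-fold higher number from compound 2 to compound 3 (0.18 log units; within the scatter) with 4-methylpiperazin-1-yl in place of (4-methylpiperazin-1-yl)methyl on a saturated chain carbon bound to a carbonyl carbon. For the measured compounds named here, no measured step covers a change of the group on the ring carbon, so the evidence for compound 4 is indirect and the range stays wide. No step beyond the scatter is therefore expected in this assay, and the expected step is a 1.4-fold lower number from compound 2 to compound 4 (0.15 log units; within the scatter) on this estimate. For compound 4 the estimated value is 90000 nM with an expected range from 30000 nM to 180000 nM in this assay.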

Compound 4, half-maximal inhibitory concentration: 120000 nM
The estimate for compound 4 lay 1.3-fold (0.12 log units) below the measured number; low and high end bracket the measured number.
By their numbers in this assay, from the lowest: compound 1; then compounds 4, 2 and 3 (each within the scatter of the next).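

Working notes on the ring carbon: in this assay the exchange of dimethylamino for piperidin-1-yl gives a 1.1-fold lower number from compound 2 to compound 4 (0.03 log units; within the scatter), the first measured change at this position, as the earlier step concerned the chain on the carbonyl carbon. On this saturated ring carbon, the entering group brings one six-membered non-aromatic ring and 6 heavy atoms in place of 3, with hydrogen-bond donor and acceptor counts unchanged, and no difference beyond the scatter appears. No measurement at hand bears on the reason for this result.

Still open, on these data alone, is whether the same holds for other groups on this ring carbon, such as morpholin-4-yl with its ring oxygen, a bare primary amine, or a longer chain on the amine nitrogen. Among the compounds shown here, also open is whether piperidin-1-yl in place of dimethylamino gives a step within the scatter on the frameworks of compound 1 and compound 3, since the single step here was read only on the framework of compound 2.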